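Chloro in Place of Methyl: From Compound 3 to Compound 4

The source may hold more compounds than are shown below. What is called first, only, known or untested is meant among the compounds shown, and "the series" means these compounds.

Measured compounds:
Compound 1: `COc1ccccc1/C=C/C(=O)c1ccc(OCC(=O)N[C@H]2CCOC2=O)cc1`
Compound 2: `CCCCCCCCCCSC(=S)N[C@H]1CCOC1=O`
Compound 3: `Cc1cc(Cl)ccc1NCC(=O)N[C@H]1CCOC1=O`

Of the compounds shown here, three sharing a lactam-bearing amide have been tested. In a functional assay on PC-3 cells (Homo sapiens) for antiproliferative activity, read by MTT assay, with a stated time of 72 h (on this read-out higher numbers stand for weaker inhibition and lower numbers for stronger inhibition), compound 1 gives 7240 nM. For compound 2 the result is only a limit of the assay, > 64000 nM. For compound 3 the outcome is likewise a limit, > 64000 nM. Among the measured compounds shown here, compound 3 therefore stands where no number is known; it sits at the limit of > 64000 nM in this assay, at which 2 of the 3 values shown sit, together with compound 2, while compound 1 is the single reading with a value.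

Compound 4, `O=C(CNc1ccc(Cl)cc1Cl)N[C@H]1CCOC1=O`, differs from compound 3 in one place: chloro in place of methyl on an aromatic carbon, ortho to a large group and meta to a chloro group. For the measured compounds named here, no measured pair shows what this exchange does. Compound 3 sits at the limit; no step size can be read from it, and nothing among the readings shown points to a gain in potency. The step is expected to be none beyond the scatter, a step that the limit leaves unreadable from compound 3 to compound 4. In this assay compound 4 is estimated at 80000 nM, within a range of 20000 nM to 300000 nM, and most probably the assay will again report only a limit for compound 4.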

Compound 4, half-maximal inhibitory concentration: > 64000 nM
Compound 4 ended at the assay's limit (the forecaster's own chance of this, stated with the estimate: 75%); the middle value is on the limit's open side.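

No step can be read between compound 3 and compound 4, as both results are limits and not numbers: the limit of > 64000 nM in this assay, at which 3 of the 4 values shown sit.

The compounds shown leave open whether chloro in place of methyl on an aromatic carbon changes the potency of compound 3 at all, in either direction, in this assay.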